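Hexylamino in place of chloro on a shared nucleoside core

The compounds below may be only part of what the source reports. "The series", "measured", "known", "first", "only" and "open" are said of these compounds alone.

Compound 1 `CCNc1nccc2c1ncn2C1O[C@H](CO)[C@@H](O)[C@H]1O`: in a functional assay on EL4 cells (Mus musculus) for inhibition, tested at 100 uM (a lower number here means less inhibition, a higher number more inhibition at the concentration tested (going by the name of the read-out)), compound 1 gives 8%
Compound 2 `OC[C@H]1OC(n2cnc3c(SCc4ccccc4)nccc32)[C@H](O)[C@@H]1O`: in this assay compound 2 gives 30%
Compound 3 `OC[C@H]1OC(n2cnc3c(Cl)nccc32)[C@H](O)[C@@H]1O`: in this assay compound 3 reaches only the limit < 5%, which is a limit of the assay and not a number

Compound 3 thus stands at the floor of this assay; its reading is the limit of < 5% in this assay, at which 1 of the 3 values shown sits, rather than a measured value. Compound 2 sits clearly above it, as the step of a number at least 25 percentage points lower from compound 2 to compound 3 (beyond the scatter) shows. Compound 1 lies close to the floor, and the step of a number at least 3 percentage points lower from compound 1 to compound 3 (that floor lies within the scatter) is within the scatter.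

Compound 4 `CCCCCCNc1nccc2c1ncn2C1O[C@H](CO)[C@@H](O)[C@H]1O` has not been measured in this assay. It differs from compound 3 by hexylamino in place of chloro on an aromatic carbon. Within the data shown here, two measured steps bear on this change. The step of a number at least 3 percentage points lower from compound 1 to compound 3 (that floor lies within the scatter) shows that an ethylamino group at this carbon gives a reading scarcely different from chloro. The step of a number 22 percentage points higher from compound 1 to compound 2 (beyond the scatter) shows that the benzylsulfanyl group at the same carbon lifts the reading modestly. Hexylamino rather than ethylamino is the untested part, so a small rise beyond the floor is expected, an estimated step of a number at least 10 percentage points higher from compound 3 to compound 4 (that floor lies within the scatter). Compound 4 is therefore expected to give 15% in this assay, within a range from 5% to 35%.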

Compound 4, a percentage reported as inhibition, at one concentration (the size of the read-out at that concentration, not a potency): 14%
Beside the measured number, compound 4's estimate is 1 percentage points above it; the measured number falls inside the stated range.
By their numbers in this assay, from the lowest: compounds 1 and 4 (each within the scatter of the next); then compound 2. At a limit, below all of these: compound 3.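

In this assay, the longer chain at this carbon brings only a number 6 percentage points higher from compound 1 to compound 4 (within the scatter), so hexylamino cannot be told apart from ethylamino here, and the added butyl stretch of chain gives no readable gain. The longer chain also does not reach what the benzylsulfanyl group gives, with a number 16 percentage points lower from compound 2 to compound 4 (beyond the scatter), so compound 2 remains the only compound shown that stands clear of all the others. Replacing chloro with hexylamino gives a number at least 9 percentage points higher from compound 3 to compound 4 (that floor lies within the scatter), and that comparison stays loose, as compound 3 is held at a limit of the assay and not at a number: the limit of < 5% in this assay, at which 1 of the 4 values shown sits.

Compound 2 and compound 4 differ both in the atom that links the group to the shared core and in the end of that group, a phenyl ring against a plain chain, so the compounds shown do not say which of the two carries the higher reading. Going by these compounds, a benzylamino or a hexylsulfanyl group at this carbon would separate the two, and whether a chain longer than hexyl changes the reading remains open.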